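The source may hold more compounds than are shown below. What is called first, only, known or untested is meant among the compounds shown, and "the series" means these compounds.

Compound 1 `N#C[C@H]1[C@@H](O)[C@H](n2cc(F)c(O)nc2=O)O[C@H](CO)[C@H]1O` — 550000 nM
Compound 2 `N#C[C@H]1[C@@H](O)[C@H](n2ccc(O)nc2=O)O[C@H](CO)[C@H]1O` — > 500000 nM (a limit)

Of the compounds shown here, two have been measured. In a functional assay on L1210 cells (Mus musculus) (on this read-out higher numbers stand for weaker inhibition and lower numbers for stronger inhibition), compound 1 gives 550000 nM. For compound 2 the measurement stopped at a limit of the assay, > 500000 nM, so no exact number is known for it. Compound 2 therefore stands at the weak end of what has been seen, and only as a limit (the limit of > 500000 nM in this assay, at which 1 of the 2 values shown sits).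

Compound 3 `N#C[C@H]1[C@@H](O)[C@H](n2ccc(N)nc2=O)O[C@H](CO)[C@H]1O` has not been measured. It differs from compound 2 in one place: amino in place of hydroxy on an aromatic carbon.

For the measured compounds named here, only one measured step exists, from compound 1 to compound 2, and its size cannot be read a step that the limit leaves unreadable from compound 1 to compound 2. Going by the values given here, it also concerns a different change than the one leading to compound 3. Among the compounds with values here, no measured step therefore tells how large the step to compound 3 should be or in which direction it should go.

With that in mind, the step from compound 2 to compound 3 is estimated as an at least 5.0-fold lower number from compound 2 to compound 3 (0.69 log units; beyond the scatter). Compound 3 is expected to give about 100000 nM, within a wide range from 2000 nM to 600000 nM, because compound 2 itself is known only as a limit > 500000 nM.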

Compound 3, half-maximal inhibitory concentration: > 750000 nM
Compound 3 gave a limit, no number; the forecaster's own chance of this, stated with the estimate: 35%; at least 7.5-fold (0.87 log units) between middle value and limit.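

In this assay compound 3 gives > 750000 nM, which is a limit and not a number. For the compounds shown here, compound 2 also stands only at a limit, so no step from compound 2 to compound 3 can be read. The compounds shown leave open whether amino in place of hydroxy on an aromatic carbon changes inhibition at all.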